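The compounds below may be only part of what the source reports. "The series", "measured", "known", "first", "only" and "open" are said of these compounds alone.

Compound 1 `CC(=O)c1ccc(OCc2ccccc2Cl)cc1` and compound 3 `CC(=O)c1ccc(OCc2ccccc2C(F)(F)F)cc1` share a core; compound 2 `CC(=O)c1ccc(OCc2ccc(Cl)cc2)cc1` is built from the same atoms as compound 1 joined differently, and the difference between the two cores is not broken down here. In an assay on isolated protein for inhibition of Amine oxidase [flavin-containing] B (Homo sapiens), read by Amplex Red, with a stated time of 15 min (on this read-out lower numbers stand for stronger inhibition and higher numbers for weaker inhibition), compound 1 gives 311 nM, compound 3 gives 183 nM, and compound 2 gives 63.2 nM, the lowest of the three numbers, with its steps to both other compounds lying beyond the scatter. One change has already been measured once: trifluoromethyl in place of chloro on an aromatic carbon, which gave a 1.7-fold lower number from compound 1 to compound 3 (0.23 log units; within the scatter). Compound 4 `CC(=O)c1ccc(OCc2ccc(C(F)(F)F)cc2)cc1` has not yet been measured in this assay. It differs from compound 2 by trifluoromethyl in place of chloro on an aromatic carbon, the same kind of change, though here the group sits para to a large group rather than ortho to a large group. Because the earlier step of a 1.7-fold lower number from compound 1 to compound 3 (0.23 log units; within the scatter) stayed within the scatter, compound 4 is expected to show a step of like size, a 1.4-fold lower number from compound 2 to compound 4 (0.15 log units; within the scatter). Compound 4 is therefore estimated at 45 nM in this assay, with a likely range from 15 nM to 150 nM.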

Compound 4, half-maximal inhibitory concentration: 77.8 nM
Compound 4: middle estimate off by 1.7-fold (0.24 log units), on the low side; low and high end bracket the measured number.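

Measured in this assay the swap of trifluoromethyl for chloro on the core of compound 2 gives a 1.2-fold higher number from compound 2 to compound 4 (0.09 log units; within the scatter) and so stays within the scatter, as it did on the core of compound 1. The two steps point in opposite directions on paper, but they cannot be told apart: the same change on two cores in this assay, a 1.7-fold lower number (0.23 log units; within the scatter) from compound 1 to compound 3 and a 1.2-fold higher number (0.09 log units; within the scatter) from compound 2 to compound 4, 2.1-fold (0.32 log units) apart, within the scatter of two such steps. In this small series, then, the swap can be carried from one core to the other as a change with no clear effect on the number, but two pairs do not show that this would hold on any further core, and they do not explain why the two groups read alike.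

The compounds shown leave open what other groups would do in place of chloro or trifluoromethyl, such as a methoxy group, a nitrile or an amine. They also leave open what would happen if the ketone end of the molecule were replaced, for instance by a carboxylic acid or an amide.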